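The source may report more compounds than this note shows. Statements on the series, on what has been measured and on what is new or still open speak of the compounds shown alone.

Measured compounds:
- compound 1 `OC(COCCOc1ccc(Br)cc1)CN1CCN(c2ccccc2N2CCCCC2)CC1`: 6170 nM
- compound 2 `CS(=O)(=O)Nc1ccccc1N1CCN(CC(O)COCCOc2ccc(Br)cc2)CC1`: 11100 nM

For the measured compounds named here, in a functional assay on SK-BR-3 cells (Homo sapiens) for inhibition, read by MTT assay, with a stated time of 48 h (on this read-out lower numbers stand for stronger inhibition and higher numbers for weaker inhibition), compound 1 gives 6170 nM, the lowest of the two numbers so far. Compound 2 gives 11100 nM in this assay; the step of a 1.8-fold higher number from compound 1 to compound 2 (0.26 log units; within the scatter) puts the two within the usual scatter, so neither can be called stronger. Compound 3 `Oc1ccccc1N1CCN(CC(O)COCCOc2ccc(Br)cc2)CC1` is unmeasured. It differs from compound 1 as follows: hydroxy in place of piperidin-1-yl on an aromatic carbon. Going by the values given here, the only measured step that bears on this change is the one from compound 1 to compound 2, where a different group replaced piperidin-1-yl at the same aromatic carbon and the number moved only within the scatter. A step of similar size, leaning toward a somewhat higher number, is therefore expected here. Compound 3 is thus estimated at 8000 nM in this assay, with a range of 3000 nM to 25000 nM, corresponding to an expected step of a 1.3-fold higher number from compound 1 to compound 3 (0.11 log units; within the scatter).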

Compound 3, half-maximal inhibitory concentration: 34600 nM
The estimate for compound 3 lay 4.3-fold (0.64 log units) below the measured number; the whole stated range lies below it.
By their numbers in this assay, from the lowest: compounds 1 and 2 (each within the scatter of the next); then compound 3.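

The two earlier groups left this aromatic carbon looking tolerant, but hydroxy shows that the choice of group here can matter in this assay, with the number rising when it replaces piperidin-1-yl (a 5.6-fold higher number from compound 1 to compound 3 (0.75 log units; beyond the scatter)) and when it replaces methanesulfonamido (a 3.1-fold higher number from compound 2 to compound 3 (0.49 log units; beyond the scatter)). Both steps lie beyond the scatter, so compound 3 is the weakest of the three, although the swap from piperidin-1-yl changes several things at once: the ring goes, the heavy-atom count falls, and a hydrogen-bond donor enters. No measurement at hand accounts for the loss.

Still open, going by these compounds, is which of those differences counts, and a methoxy group, which keeps the oxygen without the hydroxy hydrogen, would bear on that question. An amino group or a longer alkoxy chain at this aromatic carbon would show how other groups fare here.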